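Phenyl in place of hydrogen on the shared core

The source may hold more compounds than are shown below. What is called first, only, known or untested is meant among the compounds shown, and "the series" means these compounds.

The measured compounds, all in a functional assay (Oryctolagus cuniculus) for antagonist activity at platelet-activating factor receptor (Cavia porcellus); a higher number here means a weaker inhibitor, a lower number a stronger inhibitor:
compound 1 `CN(C)C(=O)n1cc(C(=O)c2ccn3c2CSC3c2cccnc2)c2ccccc21` gives 95 nM
compound 2 `CN(C)C(=O)n1cc(C(=O)c2ccn3c2CSC3c2cccnc2)c2ccc(OCc3ccccc3)cc21` gives 17 nM
compound 3 `CN(C)C(=O)n1cc(C(=O)c2ccn3c2CSC3c2cccnc2)c2ccc(Cl)cc21` gives 89 nM

Compound 1 has the highest number of the three in this assay. Compound 3 sits within the scatter of it: a 1.1-fold lower number from compound 1 to compound 3 (0.03 log units; within the scatter). Compound 2 is the one that stands apart: a 5.6-fold lower number from compound 1 to compound 2 (0.75 log units; beyond the scatter). Between the two substituted compounds the gap is likewise beyond the scatter: a 5.2-fold higher number from compound 2 to compound 3 (0.72 log units; beyond the scatter).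

Compound 4 `CN(C)C(=O)n1cc(C(=O)c2ccn3c2CSC3c2cccnc2)c2ccc(-c3ccccc3)cc21` differs from compound 1 in one place: phenyl in place of hydrogen on an aromatic carbon. Going by the values given here, two measured steps bear on it, both starting from compound 1 at the same position. The chloro step left the number where it was, while the benzyloxy step, which brings in a second aromatic ring, lowered it modestly. The phenyl of compound 4 adds an aromatic ring as benzyloxy does, but without a linking chain, so the outcome is uncertain; an intermediate step is the more cautious expectation. For compound 4 the step from compound 1 is estimated to be a 2.4-fold lower number from compound 1 to compound 4 (0.38 log units; beyond the scatter), a lowering, though it might fall within the scatter. The expected value for compound 4 is 40 nM, with a range from 15 nM to 120 nM.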

Compound 4, inhibition constant: 23 nM
Compound 4: middle estimate off by 1.7-fold (0.24 log units), on the high side; the range from low to high includes it.
By their numbers in this assay, from the lowest: compounds 2 and 4 (each within the scatter of the next); then compounds 3 and 1 (each within the scatter of the next).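

In this assay, phenyl on this aromatic carbon gives a 4.1-fold lower number from compound 1 to compound 4 (0.62 log units; beyond the scatter), so an aromatic ring attached directly lowers the number, and the linking chain of benzyloxy is not needed for this: replacing benzyloxy with phenyl gives a 1.4-fold higher number from compound 2 to compound 4 (0.13 log units; within the scatter). Replacing chloro with phenyl gives a 3.9-fold lower number from compound 3 to compound 4 (0.59 log units; beyond the scatter), so among these four compounds the two whose substituent carries an aromatic ring, compound 2 and compound 4, stand apart from compound 1 and compound 3, and none of the four goes against this division. No measurement is available that explains why these substituents differ in this way.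

The compounds shown do not tell whether the aromatic ring itself matters or whether any group of similar size would serve, and a cyclohexyl ring or a hexyl chain at this position would separate those two readings. They also leave open how a pyridyl ring, or an amine or a carboxylic acid on the added phenyl, would change the number in this assay.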